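Halogen exchange on the shared core: cytotoxicity notes

The source may hold more compounds than are shown below. What is called first, only, known or untested is meant among the compounds shown, and "the series" means these compounds.

Measured compounds:
compound 1, `O=C(Nc1ccc(I)cc1F)c1cc(F)ccc1O`, 7400 nM
compound 2, `O=C(Nc1ccc(Cl)cc1F)c1cc(F)ccc1O`, 7700 nM
compound 3, `O=C(Nc1ccc(F)cc1F)c1cc(Cl)ccc1O`, 14600 nM

Among the measured compounds shown here, in an ADME assay on RAW264.7 cells (Mus musculus) for cytotoxicity, read by MTT assay, with a stated time of 24 h (a lower number here means that less compound is tolerated, a higher number that more compound is tolerated), compound 1 gives 7400 nM and compound 2 gives 7700 nM; the one step between them, a 1.0-fold higher number from compound 1 to compound 2 (0.02 log units; within the scatter), is within the scatter. Compound 3 gives 14600 nM, the highest of the three numbers, but its gap to compound 2 and to compound 1 is in each case within the scatter, so no order among the three can be read from these data.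

Compound 4, `O=C(Nc1ccc(F)cc1F)c1cc(F)ccc1O`, has not been measured in this assay. It differs from compound 3 as follows: fluoro in place of chloro on an aromatic carbon. For the measured compounds named here, no measured step exchanges a halogen at this place on the shared core, so nothing bears on it directly; the only step at hand, from compound 1 to compound 2, is a halogen exchange elsewhere and was within the scatter. Compound 4 also shares its core with compound 2, whose value sits within the scatter of compound 3. The step of a 1.5-fold lower number from compound 3 to compound 4 (0.16 log units; within the scatter) is therefore expected to stay within the scatter. Compound 4 is estimated at 10000 nM, in a range from 5000 nM to 20000 nM.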

Compound 4, half-maximal cytotoxic concentration: 15700 nM
The estimate for compound 4 lay 1.6-fold (0.20 log units) below the measured number, within the range that was stated.
By their numbers in this assay, from the lowest: compounds 1, 2, 3 and 4 (each within the scatter of the next, the first and the last beyond it).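

In this assay, among the compounds shown here, the step of a 1.1-fold higher number from compound 3 to compound 4 (0.03 log units; within the scatter) is the first direct exchange at the place para to a hydroxy group, and it does not separate fluoro from chloro there. For the compounds shown here, the other halogen place on the shared core behaves differently: the step of a 2.0-fold higher number from compound 2 to compound 4 (0.31 log units; beyond the scatter) and the step of a 2.1-fold higher number from compound 1 to compound 4 (0.33 log units; beyond the scatter) are both modest but beyond the scatter, whereas chloro and iodo at that place were not separated by the earlier compounds. Nothing available bears on the reason for this difference between the two places.

Open, as far as these compounds go, is whether these small steps are confined to halogens, since an amine or a carboxylic acid at either place could give a different picture. Also open, from the compounds shown here alone, is how bromo compares with the other halogens at the two places.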